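The compounds below may be only part of what the source reports. "The series", "measured", "known", "first", "only" and "open" are said of these compounds alone.

In a functional assay on HL-60 cells (Homo sapiens) for cytotoxicity, read by WST assay, with a stated time of 48 h (a higher number here means a weaker inhibitor, a lower number a stronger inhibitor), compound 3 `O[C@@H](c1ccccc1)[C@H]1CO[C@H](c2ccccc2)[C@@H](C/C=C/c2ccc(F)cc2)C1` gives 8110 nM and sits level within the scatter with compound 1 `O[C@@H](c1ccccc1)[C@H]1CO[C@H](c2ccccc2)[C@@H](C/C=C/c2cccc(F)c2)C1` at 9170 nM and compound 2 `O[C@@H](c1ccccc1)[C@H]1CO[C@H](c2ccccc2)[C@@H](C/C=C/C2CCCC2)C1` at 9060 nM on these numbers. Compound 4 `O[C@@H](c1ccccc1)[C@H]1CO[C@H](c2ccccc2)[C@@H](C/C=C/c2cccnc2)C1` puts pyridin-3-yl in place of 4-fluorophenyl on a double-bonded chain carbon bound to a double-bonded chain carbon. Three measured swaps at that same place bear on this: a 1.1-fold lower number from compound 1 to compound 3 (0.05 log units; within the scatter) and a 1.1-fold lower number from compound 2 to compound 3 (0.05 log units; within the scatter) and also a 1.0-fold lower number from compound 1 to compound 2 (0.01 log units; within the scatter) all lie within the scatter. Within the data shown here, none of the measured compounds carries a ring with a hetero atom there, so this forecast remains uncertain. An estimated 1.2-fold higher number from compound 3 to compound 4 (0.09 log units; within the scatter) is expected, which is no change beyond the scatter. Compound 4 is expected at 10000 nM with an estimated range (5000 nM to 20000 nM).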

Compound 4, half-maximal inhibitory concentration: > 100000 nM
Compound 4 was reported as a limit; the forecaster's own chance of this, stated with the estimate: 15%; middle value at least 10-fold (1.00 log units) away from the limit.
By their numbers in this assay, from the lowest: compounds 3, 2 and 1 (each within the scatter of the next). At a limit, above all of these: compound 4.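

The three earlier groups at this place sat level within the scatter, which made the position look indifferent, but pyridin-3-yl gives an at least 12-fold higher number from compound 3 to compound 4 (1.09 log units; beyond the scatter) and an at least 11-fold higher number from compound 2 to compound 4 (1.04 log units; beyond the scatter) and also an at least 10-fold higher number from compound 1 to compound 4 (1.03 log units; beyond the scatter) in this series. Compound 4 gives > 100000 nM in this assay and this is a limit of the assay, not a number. The position therefore does respond to which ring it carries, even though neither fluorine nor an aromatic ring was needed in compound 2. The compounds shown leave open whether the ring nitrogen's location matters, as pyridin-4-yl would test, and whether a thiophen-2-yl ring would behave like compound 3 or compound 4.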